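This account rests on a few compounds, and the source may have more. Where it says the series, first, only, none or still open, it means among the compounds named here.

Compound 1 `Cc1cc(C)c(S(=O)(=O)N2CCC(N3CCC(CCC#N)CC3)CC2)c(C)c1` gives > 5000 nM in a functional assay on DLD-1 cells (Homo sapiens) for antiproliferative activity, read by CellTiter-Glo, with a stated time of 72 h; a lower number here means a stronger inhibitor, a higher number a weaker inhibitor. Compound 2 `Cc1cc(C)c(S(=O)(=O)N2CCC(N3CCC(Cc4ccc(F)cc4)CC3)CC2)c(C)c1` gives 18 nM.

Compound 2 holds the only number shown in this assay. The value for compound 1 is a limit of the assay, not a number, namely (the limit of > 5000 nM in this assay, at which 1 of the 2 values shown sits). Going by the values given here, the one measured step is large: an at least 270-fold lower number from compound 1 to compound 2 (2.44 log units; beyond the scatter), the gain coming when 4-fluorophenyl replaced cyanomethyl on the saturated chain carbon bound to the saturated ring carbon.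

Compound 3 `C#CCCC(=O)CC1CCN(C2CCN(S(=O)(=O)c3c(C)cc(C)cc3C)CC2)CC1` differs from compound 2 in the same position: (but-3-yn-1-yl)carbonyl in place of 4-fluorophenyl on a saturated chain carbon bound to a saturated ring carbon. This change again removes the 4-fluorophenyl ring and leaves an acyclic chain with a carbonyl and a triple bond in its place, so the measured step bears on it in reverse. A large rise in this assay is therefore expected for compound 3, with a 170-fold higher number from compound 2 to compound 3 (2.22 log units; beyond the scatter) as the estimated step. Compound 3 is estimated at 3000 nM, between 500 nM and 20000 nM.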

Compound 3, half-maximal inhibitory concentration: 3 nM
Estimate against measurement, compound 3: 1000-fold (3.00 log units) above; the whole stated range lies above it.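

The position does not depend on the 4-fluorophenyl ring: in this assay, the acyclic (but-3-yn-1-yl)carbonyl group gives a 6.0-fold lower number from compound 2 to compound 3 (0.78 log units; beyond the scatter). Lacking a ring is therefore not enough to account for the weak result with cyanomethyl, as two groups without a ring are separated by an at least 1600-fold lower number from compound 1 to compound 3 (3.22 log units; beyond the scatter). The value of compound 1 remains a limit of the assay, not a number: the limit of > 5000 nM in this assay, at which 1 of the 3 values shown sits.

The compounds shown leave open whether the carbonyl or the triple bond of the new group accounts for the step. Also open, as far as these compounds go, is how a plain pentyl chain, an amine or a carboxylic acid would fare on this saturated chain carbon in this assay.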